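Swapping a Furan for a Cyanopyridine on a Shared Core

The source may report more compounds than this note shows. Statements on the series, on what has been measured and on what is new or still open speak of the compounds shown alone.

Measured compounds:
compound 1, `CC(C)c1ccc(-c2nc(N)c3cc(Cc4ccccc4)sc3n2)o1`, 283 nM
compound 2, `CC(c1ccccc1)c1cc2c(N)nc(-c3cccc(C#N)c3)nc2s1`, 1770 nM

The account follows one step on a shared core. In a functional assay on CHO-K1 cells for antagonist activity at adenosine receptor A1 (Homo sapiens), read by a beta-galactosidase reporter and cAMP accumulation, with stated times of 15 min and 6 h (on this read-out lower numbers stand for stronger inhibition and higher numbers for weaker inhibition), compound 1 gives 283 nM, the lowest of the two numbers shown. Compound 2, `CC(c1ccccc1)c1cc2c(N)nc(-c3cccc(C#N)c3)nc2s1`, gives 1770 nM in this assay, and the gap between the two lies beyond the scatter; the two compounds differ in more than one place, so nothing is read into the cause.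

Compound 3, `N#Cc1cncc(-c2nc(N)c3cc(Cc4ccccc4)sc3n2)c1`, has not been measured. It differs from compound 1 in one place: 5-cyanopyridin-3-yl in place of 5-isopropylfuran-2-yl on an aromatic carbon. Within the data shown here, the only other compound carrying a nitrile on its aromatic substituent, compound 2, stands well above compound 1. On that basis compound 3 is expected to give a higher number than compound 1, with a step of a 2.5-fold higher number from compound 1 to compound 3 (0.39 log units; beyond the scatter) that may reach beyond the scatter. Compound 3 is therefore estimated at 700 nM, within 200 nM to 2500 nM.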

Compound 3, inhibition constant: 1160 nM
Beside the measured number, compound 3's estimate is 1.7-fold (0.22 log units) below it; measured number inside the range.
By their numbers in this assay, from the lowest: compound 1; then compounds 3 and 2 (each within the scatter of the next).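

Among these compounds, at this aromatic carbon of the shared core, between two ring nitrogen atoms, compounds 1 and 3 give the first comparison in which only one place changes. In this assay the move from 5-isopropylfuran-2-yl to 5-cyanopyridin-3-yl gives a 4.1-fold higher number from compound 1 to compound 3 (0.61 log units; beyond the scatter) and so weakens inhibition by a modest step beyond the scatter, although the two groups have the same heavy-atom count. No measurement here accounts for this step.

On these data alone, the step changes the ring, removes the isopropyl group and adds the nitrile all at once, and how much each change contributes remains open. A 5-cyanofuran-2-yl or 5-isopropylpyridin-3-yl group at this carbon would separate these changes, while a simple unsubstituted phenyl group would show how the position responds without either substituent.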